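The source may hold more compounds than are shown below. What is called first, only, known or untested is meant among the compounds shown, and "the series" means these compounds.

Compound 1 `O=C(CCc1ccc(-c2ccccc2)cc1)c1ncc(-c2ccncc2)o1` holds the lowest value among the three numbers in an assay for inhibition of Fatty-acid amide hydrolase 1 (Rattus norvegicus) (a higher number here means a weaker inhibitor, a lower number a stronger inhibitor), where compound 1 gives 2.3 nM. Compound 2 `NC(=O)c1cnc(C(=O)CCc2ccc(Oc3ccccc3)cc2)o1` is nearest, giving 6.6 nM in this assay, a gap beyond the scatter; compound 3 `COC(=O)c1ccc(-c2cnc(CCCc3ccc(-c4ccccc4)cc3)o2)nc1` lies furthest, giving 50000 nM in this assay. Compound 4 `COC(=O)c1cnc(C(=O)CCc2ccc(-c3ccccc3)cc2)o1` has not been measured. It differs from compound 1 by methoxycarbonyl in place of pyridin-4-yl on an aromatic carbon. Among the compounds with values here, no measured pair spans exactly this change. Compound 2, which also carries a small group on the shared core, shows at 6.6 nM that such a replacement can keep a low number. A modest upward step, close to the scatter, is expected: a 2.2-fold higher number from compound 1 to compound 4 (0.34 log units; beyond the scatter). Compound 4 is estimated at 5 nM, with a range of 1.5 nM to 20 nM.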

Compound 4, inhibition constant: 1.5 nM
Beside the measured number, compound 4's estimate is 3.3-fold (0.52 log units) above it; measured number inside the range.
By their numbers in this assay, from the lowest: compounds 4 and 1 (each within the scatter of the next); then compound 2; then compound 3.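

On the aromatic carbon next to the ring oxygen, methoxycarbonyl in place of pyridin-4-yl gives a 1.5-fold lower number from compound 1 to compound 4 (0.19 log units; within the scatter) in this assay. A six-membered aromatic ring at this position is therefore not required for a low number: a group with no ring serves equally well on the shared core. No data shown explain this result.

Open: whether a carboxylic acid or an amine on this same carbon also keeps the number low, and whether a longer chain on the ester oxygen does.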